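Sulfonyl hydrazide series: aryl swap on the sulfonyl

The source may report more compounds than this note shows. Statements on the series, on what has been measured and on what is new or still open speak of the compounds shown alone.

Compound 1 `CC(=O)Nc1ccc(S(=O)(=O)NNC(=O)c2cccnc2Nc2ccc(Cl)cc2)cc1` is the reference point of this set. In a functional assay on MDA-MB-231 cells (Homo sapiens) for antiproliferative activity (on this read-out lower numbers stand for higher toxicity in this test and higher numbers for lower toxicity in this test), compound 1 gives only a limit of the assay, > 100000 nM, and no number. Compound 2 `O=C(NNS(=O)(=O)c1ccc(F)cc1)c1cccnc1Nc1ccc(Cl)cc1Cl` belongs to the same series. In this assay compound 2 likewise returns only a limit, > 100000 nM. Both values sit at the same boundary of the assay (the limit of > 100000 nM in this assay, at which 2 of the 2 values shown sit), so compound 1 cannot be placed above or below compound 2; the two results show only that neither reaches a measurable concentration in this assay.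

The step to compound 3 `O=C(NNS(=O)(=O)c1ccc(Cl)cc1Cl)c1cccnc1Nc1ccc(Cl)cc1` is the change (2,4-dichlorophenyl in place of 4-acetamidophenyl on a sulfonyl sulfur), that is, 2,4-dichlorophenyl in place of 4-acetamidophenyl on a sulfonyl sulfur. Within the data shown here, no measured pair in this set tells how a change on that sulfur shifts the result in this assay, so the size of the step is not anchored by data. Given that compound 1 rests at the limit > 100000 nM, compound 3 is expected to remain at or near that boundary, with a step of a number no higher from compound 1 to compound 3 (the limit leaves the size open) that is not expected to exceed the scatter. Compound 3 is therefore estimated in this assay at 100000 nM, with a range from 30000 nM to 300000 nM.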

Compound 3, concentration lethal to 50% of the cells: > 100000 nM
Compound 3: a limit, no number; the forecaster's own chance of this, stated with the estimate: 75%; the middle value lies on the limit itself.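

No step from compound 1 to compound 3 can be read in this assay, since both results are limits of the assay and not numbers: the limit of > 100000 nM in this assay, at which 3 of the 3 values shown sit.

The compounds shown leave open whether any change on a sulfonyl sulfur shifts the result in this assay; none of them gives a number.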